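Butyl in Place of Nitro in a Tricyclic Anilide Series

A few compounds are considered here, and "the series" means these few. Any claim that something is new, unique, unknown or untested is made for them only; others in the source may bear on it.

Compound 1 `O=C1C2=C(C(=O)c3ncccc31)C1(CS2)NC(=O)N(c2ccc([N+](=O)[O-])cc2)C1=O` gives 1 nM in a functional assay on CCRF-CEM cells (Homo sapiens) for antiproliferative activity, read by MTT assay, with a stated time of 96 h (on this read-out higher numbers stand for weaker inhibition and lower numbers for stronger inhibition), the lowest of the three numbers at hand. Compound 3 `O=C1NN(c2ccc(Cl)cc2)C(=O)C2(CSC3=C2C(=O)c2ncccc2C3=O)N1` gives 50 nM and compound 2 `Cc1ccc(N2NC(=O)NC3(CSC4=C3C(=O)c3ncccc3C4=O)C2=O)cc1` gives 70 nM, both standing well beyond the scatter from compound 1. Going by the values given here, the only single-change step recorded, a 1.4-fold lower number from compound 2 to compound 3 (0.15 log units; within the scatter), concerns chloro in place of methyl and lies within the scatter; it does not speak to the change now considered. Compound 4 `CCCCc1ccc(N2C(=O)NC3(CSC4=C3C(=O)c3ncccc3C4=O)C2=O)cc1` differs from compound 1 by butyl in place of nitro on an aromatic carbon. Among the compounds with values here, no measured pair shows what butyl in place of nitro on an aromatic carbon does here, so the expected step carries a wide range. Compound 4 is estimated at 15 nM, within 2 nM to 150 nM, meaning an expected 15-fold higher number from compound 1 to compound 4 (1.18 log units; beyond the scatter).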

Compound 4, half-maximal inhibitory concentration: 150 nM
Estimate against measurement, compound 4: 10-fold (1.00 log units) below, and the stated range covers the measured number.
By their numbers in this assay, from the lowest: compound 1; then compounds 3 and 2 (each within the scatter of the next); then compound 4.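

In this assay, the change at this position, on an aromatic carbon para to a large group, gives a 150-fold higher number from compound 1 to compound 4 (2.18 log units; beyond the scatter). This is the first single-change step shown that lies beyond the scatter, so on the core of compound 1 this position is sensitive to what it carries. No measurement at hand accounts for the size of this step. Going by these compounds, what stays open is whether an amine, a nitrile or a carboxylic acid here would stay close to nitro or fall towards butyl, and whether a shorter chain would lose less.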